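This account rests on a few compounds, and the source may have more. Where it says the series, first, only, none or still open, it means among the compounds named here.

Working notes on the series built around the core of compound 1 `Cc1nn(-c2nc(-c3ccc(Cl)c(Cl)c3)c(SC(C)C)s2)c(C(=O)O)c1-c1ccccc1`. Among the compounds with values here, in a functional assay on BJAB cells (Homo sapiens) for antiproliferative activity, with a stated time of 4 days (on this read-out lower numbers stand for an effect already at smaller amounts and higher numbers for an effect only at larger amounts of compound), compound 1 gives 3000 nM, the lowest of the three numbers so far. Compound 3 `Cc1cc(C#N)cc(-c2c(C)nn(-c3nc(-c4ccc(Cl)c(Cl)c4)c(SC(C)C)s3)c2C(=O)O)c1` gives 4800 nM in this assay, and the step of a 1.6-fold higher number from compound 1 to compound 3 (0.20 log units; within the scatter) lies within the scatter, so no order between compound 1 and compound 3 can be claimed. Compound 2 `Cc1nn(-c2nc(-c3ccc(Cl)c(Cl)c3)c(SC(C)C)s2)c(C(=O)O)c1Cc1ccccc1[N+](=O)[O-]` gives 20000 nM; the step of a 6.7-fold higher number from compound 1 to compound 2 (0.82 log units; beyond the scatter) is beyond the scatter, as is a 4.2-fold lower number from compound 2 to compound 3 (0.62 log units; beyond the scatter).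

Compound 4 `Cc1nn(-c2nc(-c3ccc(Cl)c(Cl)c3)c(SC(C)C)s2)c(C(=O)O)c1-c1cccnc1` differs from compound 1 in one place: pyridin-3-yl in place of phenyl on an aromatic carbon. The step that bears most directly on it is the exchange of one six-membered aromatic ring for another, a 1.6-fold higher number from compound 1 to compound 3 (0.20 log units; within the scatter), which stayed within the scatter. The larger step of a 6.7-fold higher number from compound 1 to compound 2 (0.82 log units; beyond the scatter) involved a benzyl group and is a less close precedent. The expectation for compound 4 is therefore a step of a 1.3-fold higher number from compound 1 to compound 4 (0.12 log units; within the scatter), with no change beyond the scatter. Compound 4 is estimated at 4000 nM, within 1500 nM to 11000 nM.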

Compound 4, half-maximal effective concentration: 12000 nM
For compound 4 the middle estimate is 3.0-fold (0.48 log units) below the measured one; the whole stated range lies below it.
By their numbers in this assay, from the lowest: compounds 1 and 3 (each within the scatter of the next); then compounds 4 and 2 (each within the scatter of the next).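

At this position on the core of compound 1, in this assay, a change that keeps the 6 heavy atoms and the six-membered aromatic ring but brings in one ring nitrogen and one hydrogen-bond acceptor moves the read-out beyond the scatter, a 4.0-fold higher number from compound 1 to compound 4 (0.60 log units; beyond the scatter), whereas the earlier exchange of phenyl for 3-cyano-5-methylphenyl did not. Pyridin-3-yl also separates from that substituted aryl group, a 2.5-fold higher number from compound 3 to compound 4 (0.40 log units; beyond the scatter), but stays within the scatter of 2-nitrobenzyl, a 1.7-fold lower number from compound 2 to compound 4 (0.22 log units; within the scatter), so the three replacements do not act alike at this position. Nothing on hand gives a reason for the step.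

On these data alone, it remains open whether the step depends on where the nitrogen sits in the ring, which a pyridin-4-yl group would test. Also open, as far as these compounds go, is whether an amine or a hydroxy group on the phenyl ring would shift the number in the same direction.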